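Swapping the Aryl Group on the Shared Core

The source may hold more compounds than are shown below. What is called first, only, known or untested is meant among the compounds shown, and "the series" means these compounds.

For the measured compounds named here, in a functional assay on SGC-7901 cells (Homo sapiens) for antiproliferative activity, read by MTT assay, with a stated time of 72 h (a lower number here means a stronger inhibitor, a higher number a weaker inhibitor), compound 2, `COc1ccc(-c2ccc3ncn(-c4cc(OC)c(OC)c(OC)c4)c3c2)cc1F`, gives 430 nM, the only true number so far. Compound 1, `COc1cc(-n2cnc3ccc(-c4ccccc4Cl)cc32)cc(OC)c1OC`, is reported only as a limit, > 10000 nM.

The next compound, compound 3, `COc1cc(-n2cnc3ccc(-c4cc(F)ccc4F)cc32)cc(OC)c1OC`, has 2,5-difluorophenyl in place of the 3-fluoro-4-methoxyphenyl of compound 2 on an aromatic carbon (2,5-difluorophenyl in place of 3-fluoro-4-methoxyphenyl on an aromatic carbon). Like the 2-chlorophenyl of compound 1, the entering group carries halogen but no methoxy group. Going by the values given here, the one measured step that bears on this change is large and beyond the scatter: an at least 23-fold lower number from compound 1 to compound 2 (1.36 log units; beyond the scatter). A clear move back towards weaker inhibition in this assay is therefore expected, although a single step cannot fix its size. The expected change is a 6.0-fold higher number from compound 2 to compound 3 (0.78 log units; beyond the scatter). For compound 3 the estimate is 2600 nM, with an expected range from 700 nM to 10000 nM.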

Compound 3, half-maximal inhibitory concentration: 6590 nM
Compound 3: the middle estimate sits 2.5-fold (0.40 log units) below what was measured; low and high end bracket the measured number.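

In this assay, replacing the 3-fluoro-4-methoxyphenyl with a second halogen-only aryl group gives a large loss at this position: a 15-fold higher number from compound 2 to compound 3 (1.19 log units; beyond the scatter). The aryl group of compound 2 therefore stands apart from both the 2-chlorophenyl and the 2,5-difluorophenyl, and the earlier step alone could not show that a fluorine-bearing ring without a methoxy group would also fall so far short. The step between the two halogen-only groups is an at least 1.5-fold lower number from compound 1 to compound 3 (0.18 log units; that floor lies within the scatter). Compound 1 is known only as a limit, so that step sets no order between the two: the limit of > 10000 nM in this assay, at which 1 of the 3 values shown sits.

The compounds shown leave open whether the fluorine or the methoxy group of the 3-fluoro-4-methoxyphenyl accounts for the lower number. They also leave open how a phenyl ring carrying an amine or a carboxylic acid at this place would read in this assay.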